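A few compounds are considered here, and "the series" means these few. Any claim that something is new, unique, unknown or untested is made for them only; others in the source may bear on it.

Compound 1 `COc1cccc(/C=C2\CCC/C(=C\c3ccccc3Br)C2=O)c1OC`: 9700 nM 
Compound 2 `COc1cccc(/C=C2\CCC/C(=C\c3ccc(O)cc3)C2=O)c1OC`: > 20000 nM (a limit)

Going by the values given here, in a functional assay on MCF7 cells (Homo sapiens) for cytotoxicity, read by MTT assay, with a stated time of 72 h (on this read-out higher numbers stand for weaker inhibition and lower numbers for stronger inhibition), compound 1 gives 9700 nM as the only true number so far. Compound 2 stands at > 20000 nM and this is a limit of the assay, not a number.

Compound 3 `COc1cccc(/C=C2\CCC/C(=C\c3ccc(Cl)cc3Cl)C2=O)c1OC` differs from compound 2 by 2,4-dichlorophenyl in place of 4-hydroxyphenyl on a double-bonded chain carbon bound to a double-bonded ring carbon with 2,4-dichlorophenyl in place of 4-hydroxyphenyl, on a double-bonded chain carbon bound to a double-bonded ring carbon. Among the compounds with values here, one measured step bears on this place: an at least 2.0-fold higher number from compound 1 to compound 2 (0.31 log units; beyond the scatter) on bringing in the 4-hydroxyphenyl. Compound 3 gives up that group again, so compound 1 at 9700 nM is the closest guide, though its 2-bromophenyl is not the same group. The expected step is an at least 2.5-fold lower number from compound 2 to compound 3 (0.39 log units; beyond the scatter) in this assay toward stronger inhibition, its size loosely held since one end is a limit. Compound 3 is estimated at 8000 nM with an expected range of 3000 nM to 20000 nM for the measurement.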

Compound 3, half-maximal inhibitory concentration: > 20000 nM
Compound 3: no number, only a limit; the forecaster's own chance of this, stated with the estimate: 15%; at least 2.5-fold (0.39 log units) between middle value and limit.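

Replacing 2-bromophenyl with 2,4-dichlorophenyl on a double-bonded chain carbon bound to a double-bonded ring carbon gives an at least 2.0-fold higher number from compound 1 to compound 3 (0.31 log units; beyond the scatter) in this assay, so removing the 4-hydroxyphenyl does not by itself restore a true number. Compound 3 gives > 20000 nM, a limit and not a number, and it carries 0 hydrogen-bond donors at this place, so a hydrogen-bond donor is not needed for a compound to reach the limit. The step from compound 2 to compound 3 cannot be read, and the readable range at this place is narrow: the limit of > 20000 nM in this assay, at which 2 of the 3 values shown sit.

From the compounds shown here alone, whether a plain phenyl, a 2-chlorophenyl or a phenyl carrying an amine gives a true number at this place remains open. With a single true number in the series, no order among these groups can be drawn.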